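A few compounds are considered here, and "the series" means these few. Any claim that something is new, unique, unknown or untested is made for them only; others in the source may bear on it.

Working notes on the series.

Compound 2 `c1ccc2c(-c3cn4ccnc4c(-c4ccc5ncn(C6CCCCC6)c5c4)n3)cccc2c1` gives 11.1% in a functional assay on KM12 cells (Homo sapiens) for inhibition, read by sulforhodamine B assay, with a stated time of 48 h, tested at 10 uM; a lower number here means less inhibition, a higher number more inhibition at the concentration tested (going by the name of the read-out); compound 3 `CC(=O)c1ccc(-c2cn3ccnc3c(-c3ccc4ncn(C5CCCCC5)c4c3)n2)cc1` gives 11.7%, within the scatter of compound 2, and compound 1 `c1ccc(-c2cn3ccnc3c(-c3ccc4ncn(C5CCCCC5)c4c3)n2)cc1` gives 49%, so the step of a number 37.9 percentage points lower from compound 1 to compound 2 (beyond the scatter) is the only one beyond the scatter that involves compound 2. Compound 4 `Brc1ccc(-c2cn3ccnc3c(-c3ccc4ncn(C5CCCCC5)c4c3)n2)cc1` differs from compound 2 by 4-bromophenyl in place of naphthalen-1-yl on an aromatic carbon. The step of a number 37.9 percentage points lower from compound 1 to compound 2 (beyond the scatter) bears on this directly, since it is the same change in reverse apart from the bromine; the step of a number 37.3 percentage points lower from compound 1 to compound 3 (beyond the scatter) and the step of a number 0.6 percentage points higher from compound 2 to compound 3 (within the scatter) show what another substituent on the phenyl did. Whether bromine behaves like hydrogen or like acetyl is not shown. A rise is expected, a number 18.9 percentage points higher from compound 2 to compound 4 (beyond the scatter), landing compound 4 at an estimated 30%, in the range 8% to 55%.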

Compound 4, a percentage reported as inhibition, at one concentration (the size of the read-out at that concentration, not a potency): 23.3%
Compound 4: the middle estimate sits 6.7 percentage points above what was measured; low and high end bracket the measured number.
By their numbers in this assay, from the lowest: compounds 2 and 3 (each within the scatter of the next); then compound 4; then compound 1.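

In this assay, the bromo analogue separates from both earlier low compounds: a number 12.2 percentage points higher from compound 2 to compound 4 (beyond the scatter) and a number 11.6 percentage points higher from compound 3 to compound 4 (beyond the scatter), so bromo and acetyl on the phenyl are not interchangeable in this series. Bromo also does not match hydrogen, with a number 25.7 percentage points lower from compound 1 to compound 4 (beyond the scatter) as the step. Each replacement of the phenyl of compound 1 lowers the number, and 4-bromophenyl lowers it least.

As far as these compounds go, whether an amine or a carboxylic acid in place of the bromo would restore the number of compound 1 remains open. No supporting measurement explains the order of these groups.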